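An amide-bearing arm replaces an aryl ring on the triazole

The compounds below may be only part of what the source reports. "The series", "measured", "known", "first", "only" and "open" are said of these compounds alone.

Compound 1 `CCOC(=O)C1=Cc2ccccc2OC1(OCc1cn(-c2ccc(F)cc2)nn1)C(F)(F)F` is the reference point of this set. In a functional assay on DU-145 cells (Homo sapiens) for inhibition, read by MTT assay, with a stated time of 24 h (on this read-out higher numbers stand for weaker inhibition and lower numbers for stronger inhibition), compound 1 gives 8900 nM, the lowest of the two numbers reported. Compound 2 `O=C(O)C1=Cc2ccccc2OC1(OCc1cc(-c2ccc(F)cc2)no1)C(F)(F)F`, a carboxylic acid on a core that carries an isoxazole-linked 4-fluorophenyl group, gives 168000 nM in this assay, a gap that lies beyond the scatter. Compound 3 `CCOC(=O)C1=Cc2ccccc2OC1(OCc1cc(-c2ccc(OC)cc2)no1)C(F)(F)F` reaches only a limit of the assay in this assay, > 150000 nM, and no number is known for it (the limit of > 150000 nM in this assay, at which 1 of the 3 values shown sits). No two of these compounds differ in one place alone, so no single change among them has a measured size.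

Compound 4 `CCOC(=O)C1=Cc2ccccc2OC1(OCc1cn(CC(=O)Nc2cccc(F)c2)nn1)C(F)(F)F` has not been measured. It differs from compound 1 in one place: ((3-fluorophenyl)carbamoyl)methyl in place of 4-fluorophenyl on an aromatic nitrogen. Going by the values given here, with no matching step among the measured compounds, the direction of this change is uncertain; a modest loss of potency, within or somewhat beyond the scatter, is the expectation, since compound 1 at 8900 nM already stands at the better end of what this set shows. The step from compound 1 to compound 4 is therefore estimated at a 1.8-fold higher number from compound 1 to compound 4 (0.25 log units; within the scatter). For compound 4 the expected value is 16000 nM, with a likely range from 4500 nM to 60000 nM.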

Compound 4, half-maximal inhibitory concentration: > 150000 nM
Compound 4: no number, only a limit; the forecaster's own chance of this, stated with the estimate: 10%; at least 9.3-fold (0.97 log units) between middle value and limit.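

In this assay, going by these compounds alone, putting ((3-fluorophenyl)carbamoyl)methyl in place of 4-fluorophenyl on the aromatic nitrogen gives an at least 16-fold higher number from compound 1 to compound 4 (1.22 log units; beyond the scatter), the first single change in this set with a size beyond the scatter. The entering group still carries a fluorinated six-membered aromatic ring, so an aryl ring within the group on this nitrogen is not enough to retain the potency of compound 1. For compound 4 the read-out is a limit of the assay, > 150000 nM, and not a number, so the step has no upper end: the limit of > 150000 nM in this assay, at which 2 of the 4 values shown sit.

The change alters the arm and the place of the fluorine together, and the compounds shown do not separate these. From the compounds shown here alone, how a 3-fluorophenyl or a 3-fluorobenzyl group on this nitrogen would read remains open.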